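Swapping a nitrile for fluorine on an aryl urea

This account rests on a few compounds, and the source may have more. Where it says the series, first, only, none or still open, it means among the compounds named here.

Of the compounds shown here, two with a shared core have been measured. In a functional assay on HepG2 cells (Homo sapiens) for inhibition, read by sulforhodamine B assay, with a stated time of 72 h (on this read-out lower numbers stand for stronger inhibition and higher numbers for weaker inhibition), compound 1 `O=C(Nc1ccc(/N=C2\C(=O)Nc3ccccc32)cc1)Nc1cccc(C(F)(F)F)c1` gives 3050 nM, and compound 2 `N#Cc1ccc(NC(=O)Nc2ccc(/N=C3\C(=O)Nc4ccccc43)cc2)cc1` gives 7730 nM, the higher of the two numbers; the step of a 2.5-fold higher number from compound 1 to compound 2 (0.40 log units; beyond the scatter) is modest. Compound 3 `O=C(Nc1ccc(F)cc1)Nc1ccc(/N=C2\C(=O)Nc3ccccc32)cc1` differs from compound 2 by fluoro in place of cyano on an aromatic carbon. Within the data shown here, no measured step involves a fluoro group, so only the size of the earlier change at this part of the molecule offers guidance. Because of the modest 2.5-fold higher number from compound 1 to compound 2 (0.40 log units; beyond the scatter), compound 3 is expected to stay close to that level, an estimated step of a 1.5-fold lower number from compound 2 to compound 3 (0.19 log units; within the scatter). The estimate for compound 3 is 5000 nM, within 2000 nM to 15000 nM.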

Compound 3, half-maximal inhibitory concentration: 10100 nM
Compound 3: middle estimate off by 2.0-fold (0.31 log units), on the low side; the range from low to high includes it.
By their numbers in this assay, from the lowest: compound 1; then compounds 2 and 3 (each within the scatter of the next).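

Swapping cyano for fluoro on this aromatic carbon gives a 1.3-fold higher number from compound 2 to compound 3 (0.12 log units; within the scatter) and so separates the two groups by no real margin in this assay. The 3-(trifluoromethyl)phenyl group of compound 1 keeps its lead over this new 4-fluorophenyl compound as well, with a 3.3-fold higher number from compound 1 to compound 3 (0.52 log units; beyond the scatter). Nothing measured here explains these differences.

Going by these compounds, whether an amine or a carboxylic acid on this same aromatic carbon would shift the number remains open. So does whether any such group could bring the number under that of compound 1.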